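This account rests on a few compounds, and the source may have more. Where it says the series, first, only, none or still open, it means among the compounds named here.

Measured compounds in a functional assay on DU-145 cells (Homo sapiens) for inhibition, read by MTT assay, with a stated time of 72 h; a higher number here means a weaker inhibitor of growth, a lower number a stronger inhibitor of growth:
compound 1 `N#C/C(=C\c1ccc(Cl)cc1)C(=O)c1ccc[nH]1`, 61000 nM;
compound 2 `COc1ccc(CNC(=O)/C(C#N)=C/c2ccc[nH]2)cc1`, > 50000 nM;
compound 3 `COc1ccc(CNC(=O)/C(C#N)=C/c2ccc(C)o2)cc1`, 39000 nM.

Compound 2 reaches only the limit of this assay, > 50000 nM, and so gives no number. The values of compound 3 and compound 1 in this assay lie within the scatter of each other, so nothing separates them; the third value shown is the limit just named (the limit of > 50000 nM in this assay, at which 1 of the 3 values shown sits). For the measured compounds named here, the one measured step with a number on at least one side, an at least 1.2-fold lower number from compound 2 to compound 3 (0.10 log units; that floor lies within the scatter), replaces one five-membered ring by another and is bounded only at a floor that itself lies within the scatter.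

Compound 4 `COc1ccc(CNC(=O)/C(C#N)=C/c2ccc(Br)o2)cc1` is not yet measured. It differs from compound 3 by bromo in place of methyl on an aromatic carbon, in words bromo in place of methyl on an aromatic carbon. Going by the values given here, no measured step exchanges one substituent for another on this ring; the only step recorded changes the ring itself and is small. On that basis no step beyond the scatter is expected in this assay, in either direction, and the estimate for compound 4 is 35000 nM, with a range from 12000 nM to 90000 nM. The expected step from compound 3 to compound 4 is a 1.1-fold lower number from compound 3 to compound 4 (0.05 log units; within the scatter).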

Compound 4, concentration for 50% growth inhibition: 12000 nM
Beside the measured number, compound 4's estimate is 2.9-fold (0.46 log units) above it; the measured number falls inside the stated range.
By their numbers in this assay, from the lowest: compound 4; then compounds 3 and 1 (each within the scatter of the next).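

In this assay, bromo in place of methyl on an aromatic carbon next to the ring oxygen gives a 3.3-fold lower number from compound 3 to compound 4 (0.51 log units; beyond the scatter), the first sign that a substituent exchange at this position can produce a step beyond the scatter. The ring exchange alone had shown only an at least 1.2-fold lower number from compound 2 to compound 3 (0.10 log units; that floor lies within the scatter), whereas the comparison with bromo on the ring reads an at least 4.1-fold lower number from compound 2 to compound 4 (0.61 log units; beyond the scatter). Compound 2 gives > 50000 nM, which is a limit and not a number, so the step to it is a floor only: the limit of > 50000 nM in this assay, at which 1 of the 4 values shown sits.

This position rests on a single pair, which cannot separate a gain from bromo from a loss from methyl, and a plain hydrogen, an amine or a carboxylic acid on the same carbon would be needed to show how far the position responds and in which direction. Also open, going by these compounds, is whether bromo would give a comparable step on the 1H-pyrrol-2-yl ring of compound 2, where the present data hold no substituent exchange at all.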